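The source may report more compounds than this note shows. Statements on the series, on what has been measured and on what is new or still open speak of the compounds shown alone.

Measured in a functional assay on NCI-N87 cells (Homo sapiens) for antiproliferative activity; on this read-out higher numbers stand for weaker inhibition and lower numbers for stronger inhibition:
- compound 1 (`C#Cc1cccc(Nc2ncnn3ccc(COC[C@@H]4CNCCO4)c23)c1`): 4400 nM
- compound 2 (`NC1CCN(Cc2ccn3ncnc(Nc4ccccc4)c23)CC1`): 140 nM
- compound 3 (`CC(C)Nc1ncnn2ccc(CN3CCC(N)CC3)c12`): "not determined" (no result reported)

Compound 3 therefore has no number in this assay and gives no starting value. Compound 4 (`COc1ccc(Nc2ncnn3ccc(CN4CCC(N)CC4)c23)cc1Cl`) has 3-chloro-4-methoxyphenyl in place of isopropyl on a nitrogen on an aromatic ring. Within the data shown here, no measured step shows what this exchange does, so its size cannot be read from the data. The closest guide is compound 2 at 140 nM, which shares the side chain of compound 4 and also has an aromatic ring on that nitrogen. Compound 4 is expected to lie near compound 2, with no step beyond the scatter anticipated. The estimate for compound 4 is 100 nM, with an expected range of 20 nM to 500 nM.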

Compound 4, half-maximal inhibitory concentration: 1210 nM
Estimate against measurement, compound 4: 12-fold (1.08 log units) below; the measured number lies above the stated range.
By their numbers in this assay, from the lowest: compound 2; then compound 4; then compound 1.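

In this assay, the aromatic ring on this nitrogen tolerates substitution poorly in this one pair: 3-chloro-4-methoxyphenyl in place of phenyl gives an 8.6-fold higher number from compound 2 to compound 4 (0.94 log units; beyond the scatter). A change on that ring alone therefore moves the read-out beyond the scatter, with the plain phenyl holding the lower number. Nothing available accounts for the size of this step.

The exchange of isopropyl cannot be read, as compound 3 has no number. Whether the chlorine or the methoxy carries the step remains open, as a phenyl bearing only one of them is not among the compounds shown.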